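A few compounds are considered here, and "the series" means these few. Any claim that something is new, unique, unknown or untested is made for them only; others in the source may bear on it.

The measured compounds so far:

Compound 1, `OC(Cc1ccccc1)c1cccc2[nH]ncc12`: in an assay for inhibition of Indoleamine 2,3-dioxygenase 1 variant C129Y (Homo sapiens), read by spectrophotometry, with a stated time of 30 min, tested at 10 uM (a higher number here means more inhibition at the concentration tested (going by the name of the read-out), a lower number less inhibition), compound 1 gives 14%.
Compound 2, `Cc1cc(C(O)Cc2ccccc2)c2cn[nH]c2c1`: in this assay compound 2 gives 18%.
Compound 3, `C#Cc1cc(C(O)Cc2ccccc2)c2cn[nH]c2c1`: in this assay compound 3 gives 12%.

Compound 3 carries the smallest of the three numbers, yet its gaps to both neighbours lie within the scatter of repeated measurements, so the three compounds cannot be told apart on these readings; all sit at modest inhibition at the tested concentration.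

Compound 4, `CCc1cc(C(O)Cc2ccccc2)c2cn[nH]c2c1`, differs from compound 3 in one place: ethyl in place of ethynyl on an aromatic carbon.

For the measured compounds named here, three measured steps concern the same aromatic carbon. Adding a methyl gave a number 4 percentage points higher from compound 1 to compound 2 (within the scatter), adding an ethynyl gave a number 2 percentage points lower from compound 1 to compound 3 (within the scatter), and swapping methyl for ethynyl gave a number 6 percentage points lower from compound 2 to compound 3 (within the scatter). Going by the values given here, none of these exchanges reached beyond the scatter, and no measured pair swaps an ethynyl for an ethyl directly. Among the compounds with values here, since every change at this position so far left the reading essentially unchanged, the ethyl is expected to do the same, and the step from compound 3 to compound 4 is estimated as a number 4 percentage points higher from compound 3 to compound 4 (within the scatter), not beyond the scatter.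

Compound 4 is therefore expected to give about 16% in this assay, within a range from 6% to 26%.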

Compound 4, a percentage reported as inhibition, at one concentration (the size of the read-out at that concentration, not a potency): 18%
Compound 4: the middle estimate sits 2 percentage points below what was measured, within the range that was stated.
By their numbers in this assay, from the lowest: compounds 3, 1, 2 and 4 (each within the scatter of the next).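

In this assay, ethyl in place of ethynyl gave a number 6 percentage points higher from compound 3 to compound 4 (within the scatter), so exchanging a group with a triple bond outside aromatic rings for one of equal heavy-atom count without it did not move the reading beyond the scatter at this aromatic carbon. Extending the methyl of compound 2 to the ethyl of compound 4 gave no change at the digits printed from compound 2 to compound 4 (within the scatter), and ethyl in place of hydrogen gave a number 4 percentage points higher from compound 1 to compound 4 (within the scatter), so neither a longer saturated group nor the addition of ethyl to the unsubstituted compound separated these readings. Nothing available here bears on why the readings stay so close.

Going by these compounds, it remains open whether a larger or chemically different group at this aromatic carbon, such as an amine, a carboxylic acid or a longer chain such as hexyl, would produce a step beyond the scatter. All four compounds also share the rest of their structure, so the effect of replacing the hydroxyl on the saturated chain with an amine, or of other changes away from this carbon, cannot be judged from them.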